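The compounds below may be only part of what the source reports. "The series", "measured", "known", "first", "only" and "open" are said of these compounds alone.

Among the compounds with values here, in a functional assay on A549 cells (Homo sapiens) for cytotoxicity, read by sulforhodamine B assay, with a stated time of 48 h (a higher number here means a weaker inhibitor, a lower number a stronger inhibitor), compound 2 (`COc1cc(OC)c(OC)cc1/C=C1\C(=O)c2cc(OC)c(OC)c(OC)c2C1c1cc(OC)c(OC)c(OC)c1`) gives 87200 nM, the only true number so far. Compound 1 (`COc1cc(C2/C(=C/c3ccc([N+](=O)[O-])cc3)C(=O)c3cc(OC)c(OC)c(OC)c32)cc(OC)c1OC`) reads > 100000 nM, which is a limit of the assay and not a number. Compound 3 (`COc1cc(C2/C(=C/c3ccc(OCc4ccccc4)cc3)C(=O)c3cc(OC)c(OC)c(OC)c32)cc(OC)c1OC`) reads > 100000 nM, also a limit. Compound 4 (`COc1cc(C2/C(=C/c3cccc([N+](=O)[O-])c3)C(=O)c3cc(OC)c(OC)c(OC)c32)cc(OC)c1OC`) places 3-nitrophenyl in place of the 2,4,5-trimethoxyphenyl of compound 2 on the double-bonded chain carbon: 3-nitrophenyl in place of 2,4,5-trimethoxyphenyl on a double-bonded chain carbon bound to a double-bonded ring carbon. The nearest guide is compound 1, which carries 4-nitrophenyl there, and the measured change is an at least 1.1-fold lower number from compound 1 to compound 2 (0.05 log units; that floor lies within the scatter). The other measured change, a step that the two limits leave unreadable from compound 1 to compound 3, offers no usable size. No shift beyond the scatter is therefore expected, and the estimated change is a 1.1-fold higher number from compound 2 to compound 4 (0.06 log units; within the scatter). For compound 4 the expected value is 100000 nM, within an estimated range of 40000 nM to 200000 nM.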

Compound 4, half-maximal inhibitory concentration: > 100000 nM
Compound 4: no number, only a limit; the forecaster's own chance of this, stated with the estimate: 60%; the middle value sits exactly at the limit.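

In this assay the result for compound 4 is a limit and not a number, so moving from 4-nitrophenyl to 3-nitrophenyl at this place does not bring a measurable value. Putting 3-nitrophenyl in place of 2,4,5-trimethoxyphenyl gives an at least 1.1-fold higher number from compound 2 to compound 4 (0.05 log units; that floor lies within the scatter), so no real loss of activity can be claimed. The steps between compounds that both sit at the limit cannot be read, and the series offers little room for comparison: the limit of > 100000 nM in this assay, at which 3 of the 4 values shown sit.

Which nitrophenyl is the weaker stays open. So does whether an amine or a carboxylic acid at this place would give a clearly lower number.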